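Capping the hydroxy group of compound 1 as methoxy

This account rests on a few compounds, and the source may have more. Where it says the series, first, only, none or still open, it means among the compounds named here.

Two compounds have been measured in a functional assay on NCI-H226 cells (Homo sapiens) for inhibition, read by sulforhodamine B assay, with a stated time of 48 h, tested at 0.1 uM; a lower number here means a stronger effect, a higher number a weaker effect of the compound at the concentration tested:
compound 1, `O=C(Nc1cccc(-n2cc(-c3ccncc3)c(-c3cc(O)cc(Cl)c3)n2)c1)Nc1ccc(Cl)c(C(F)(F)F)c1`, 95%
compound 2, `O=C(Nc1cccc(-n2cc(-c3ccncc3)c(-c3cc(O)cc(Cl)c3)n2)c1)Nc1ccc(Cl)c(Cl)c1`, 89%

Compound 1 holds the nominally higher of these two numbers, yet the step of a number 6 percentage points lower from compound 1 to compound 2 (within the scatter) leaves compound 2 inside the scatter of compound 1. Compound 3, `COc1cc(Cl)cc(-c2nn(-c3cccc(NC(=O)Nc4ccc(Cl)c(C(F)(F)F)c4)c3)cc2-c2ccncc2)c1`, has not yet been measured in this assay. It differs from compound 1 by methyl in place of hydrogen on an oxygen on an aromatic ring. For the measured compounds named here, the single measured step concerns another place, chloro in place of trifluoromethyl, so no measured step bears on this change, and no step beyond the scatter is expected in this assay. Compound 3 is therefore estimated at 93%, between 78% and 104%. This estimate means an expected step of a number 2 percentage points lower from compound 1 to compound 3 (within the scatter).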

Compound 3, a percentage reported as activity, at one concentration (the size of the read-out at that concentration, not a potency): 96%
Compound 3: the middle estimate sits 3 percentage points below what was measured; low and high end bracket the measured number.
By their numbers in this assay, from the lowest: compounds 2, 1 and 3 (each within the scatter of the next).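

Read in this assay the change from hydroxy to methoxy gives a number 1 percentage points higher from compound 1 to compound 3 (within the scatter) so a methyl on this oxygen leaves the read-out inside the scatter. The hydrogen of the hydroxy group is therefore not needed for the number seen at this concentration, and this position accepts the added carbon without a readable step. No evidence on hand speaks to why this change leaves the number in place. As far as these compounds go, whether a longer chain on this oxygen, or an amine in place of the hydroxy group, would do the same remains open.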